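Adding One Hydroxymethyl to the Side Chain of Compound 1

The compounds below may be only part of what the source reports. "The series", "measured", "known", "first", "only" and "open" are said of these compounds alone.

Measured so far in an ADME assay on HepG2 2.2.15 cells (Homo sapiens) for cytotoxicity, read by MTT assay, with a stated time of 8 days; on this read-out higher numbers stand for lower toxicity in this test and lower numbers for higher toxicity in this test:
- Compound 1 `N#Cc1ccc(Cn2nc(-c3cc(Cl)c(NCCO)nc3F)c3ccccc3c2=O)cc1`: 32100 nM
- Compound 2 `CC(C)c1cc(-c2ccc(F)nc2F)nn(Cc2ccc(Cl)cc2)c1=O`: 56700 nM
- Compound 3 `Cc1nc(-c2ccc(F)nc2F)cn(Cc2ccc(Cl)cc2)c1=O`: > 100000 nM, which is a limit of the assay and not a number

Compound 1, at 32100 nM, and compound 2, at 56700 nM, lie within the usual scatter of each other in this assay. Going by the values given here, these are the only two exact numbers available.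

Compound 4 `N#Cc1ccc(Cn2nc(-c3cc(Cl)c(NC[C@@H](O)CO)nc3F)c3ccccc3c2=O)cc1` has not yet been measured. It differs from compound 1 in one place: hydroxymethyl in place of hydrogen on a saturated chain carbon bound to an oxygen on a saturated carbon and a saturated chain carbon. Hydroxymethyl takes the place of hydrogen on a saturated chain carbon, which turns the (2-hydroxyethyl)amino group into (2,3-dihydroxypropyl)amino.

Among the compounds with values here, no measured pair shows this change, so the only guide is compound 1 at 32100 nM, the one measured compound with the same core. In this assay, no shift beyond the scatter is expected, in either direction. The expected step of a 1.2-fold higher number from compound 1 to compound 4 (0.10 log units; within the scatter) is therefore small. For compound 4 the estimated value is 40000 nM, with an expected range of 15000 nM to 100000 nM.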

Compound 4, half-maximal cytotoxic concentration: > 100000 nM
Compound 4: no number, only a limit; the forecaster's own chance of this, stated with the estimate: 20%; at least 2.5-fold (0.39 log units) between middle value and limit.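

The earlier compounds shown here offered no pair differing in one place, and this first pair shows that in this assay hydroxymethyl in place of hydrogen on this saturated chain carbon gives an at least 3.1-fold higher number from compound 1 to compound 4 (0.49 log units; beyond the scatter), a shift beyond the scatter toward lower toxicity in this test. Compound 4 gives > 100000 nM, which is a limit of the assay and not a number. The step can therefore be read only as a minimum, because the value of compound 4 sits at the end of the range that the assay reports: the limit of > 100000 nM in this assay, at which 2 of the 4 values shown sit.

From the compounds shown here alone, whether an amine, a carboxylic acid or a longer chain at this same carbon would shift the read-out in the same way remains open. Also open, going by these compounds, is whether the mirror-image form of the (2,3-dihydroxypropyl)amino group would behave like compound 4.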